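A few compounds are considered here, and "the series" means these few. Any claim that something is new, unique, unknown or untested is made for them only; others in the source may bear on it.

Measured so far in a functional assay on KB cells (Homo sapiens) for antiproliferative activity, read by MTT assay, with a stated time of 72 h; a higher number here means a weaker inhibitor, a lower number a stronger inhibitor: compound 1 `Cc1ccc(S(=O)(=O)N(C)c2ccc3[nH]c(-c4n[nH]c5ccccc45)cc3n2)cc1` gives 9500 nM; compound 2 `COc1ccc(OC)c(S(=O)(=O)N(C)c2ccc3[nH]c(-c4n[nH]c5ccccc45)cc3n2)c1` gives 4380 nM.

Compound 2 stands lowest of the two numbers, separated from compound 1 by a 2.2-fold lower number from compound 1 to compound 2 (0.34 log units; beyond the scatter). Compound 3 `CN(c1ccc2[nH]c(-c3n[nH]c4ccccc34)cc2n1)S(=O)(=O)c1ccc(OC(F)(F)F)cc1` differs from compound 2 by 4-(trifluoromethoxy)phenyl in place of 2,5-dimethoxyphenyl on a sulfonyl sulfur. Among the compounds with values here, the only step bearing on this is the one from compound 1 to compound 2, and it was modest. Compound 3 returns to a sulfonyl aryl group nearer to that of compound 1 than to that of compound 2, so a modest move back toward the number of compound 1 is expected, a 1.6-fold higher number from compound 2 to compound 3 (0.20 log units; within the scatter). Compound 3 is estimated at 7000 nM, between 3000 nM and 18000 nM.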

Compound 3, half-maximal inhibitory concentration: 1330 nM
Compound 3: the middle estimate sits 5.3-fold (0.72 log units) above what was measured; measured number below the stated range.
By their numbers in this assay, from the lowest: compound 3; then compound 2; then compound 1.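

In this assay the aryl group on the sulfonyl sulfur is a real handle: the trifluoromethoxy for methyl exchange gives a 7.1-fold lower number from compound 1 to compound 3 (0.85 log units; beyond the scatter) and the swap away from 2,5-dimethoxyphenyl gives a 3.3-fold lower number from compound 2 to compound 3 (0.52 log units; beyond the scatter) and so places compound 3 lowest of the three. A single ring substituent therefore does not by itself return the number toward that of compound 1; the identity of the group matters. No measurement on hand accounts for this.

Open, as far as these compounds go, is whether the trend extends to other groups on this ring, such as an amine, a carboxylic acid or a nitrile. From the compounds shown here alone, the effect of replacing the methyl on the sulfonamide nitrogen also remains open.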